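This account rests on a few compounds, and the source may have more. Where it says the series, first, only, none or still open, it means among the compounds named here.

In an assay on isolated protein for inhibition of thyroid hormone receptor beta (Homo sapiens), read by fluorescence, with a stated time of 30 min (on this read-out higher numbers stand for weaker inhibition and lower numbers for stronger inhibition), compound 2 `COc1cc(C(=O)N2CCC(O)C(C)C2)cc2nc(NCc3cccc(Cl)n3)oc12` gives 580 nM. Among the measured compounds shown here, that is the higher of the two numbers measured so far; its nearest neighbour, compound 1 `COc1cc(C(=O)N2CCC(O)C(C)C2)cc2nc(NCc3cccc(Cl)c3)oc12`, gives 25 nM in this assay. For the measured compounds named here, the only measured step between them is a 23-fold higher number from compound 1 to compound 2 (1.37 log units; beyond the scatter). Compound 3 `COc1cc(C(=O)N2CCC(O)C(C)C2)cc2nc(NCc3cc(Cl)ccc3F)oc12` has not yet been measured. It differs from compound 2 by 5-chloro-2-fluorophenyl in place of 6-chloropyridin-2-yl on a saturated chain carbon bound to a nitrogen on an aromatic ring. That one measured step bears directly on this change, because a 23-fold higher number from compound 1 to compound 2 (1.37 log units; beyond the scatter) shows what happened when a ring of carbon only carrying a chlorine gave way to the pyridinyl ring; compound 3 brings back a ring of carbon only carrying a chlorine, now with a fluorine added, so the number is expected to fall again, though not necessarily all the way. The step is estimated as a 13-fold lower number from compound 2 to compound 3 (1.11 log units; beyond the scatter). Compound 3 is therefore expected to give 45 nM in this assay, within a range from 12 nM to 170 nM.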

Compound 3, half-maximal inhibitory concentration: 300 nM
Beside the measured number, compound 3's estimate is 6.7-fold (0.82 log units) below it; the measured number lies above the stated range.
By their numbers in this assay, from the lowest: compound 1; then compounds 3 and 2 (each within the scatter of the next).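

Returning to a ring of carbon only does not by itself bring back the number of compound 1: a 1.9-fold lower number from compound 2 to compound 3 (0.29 log units; within the scatter), so 5-chloro-2-fluorophenyl and 6-chloropyridin-2-yl cannot be told apart at this position in this assay. Fluoro in place of hydrogen on an aromatic carbon is a large step in its own right, a 12-fold higher number from compound 1 to compound 3 (1.08 log units; beyond the scatter), which shows that this position responds strongly to a single substitution on the ring as well as to a ring nitrogen. Nothing available here explains either result.

From the compounds shown here alone, it remains open whether this loss is specific to fluoro or would also follow a methyl or methoxy group on the same carbon. Going by these compounds, it is also open how a pyridinyl ring carrying both chlorine and fluorine would compare with compound 3.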